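This account rests on a few compounds, and the source may have more. Where it says the series, first, only, none or still open, it means among the compounds named here.

The measured compounds:
compound 1, `CC(O)c1ccc(C(=O)N[C@@H](C)Cn2ccc(-c3ccc(C#N)c(Cl)c3)n2)cc1`: 910 nM in a functional assay on VCaP cells (Homo sapiens) for antiproliferative activity, read by CCK-8 assay, with a stated time of 6 days; on this read-out higher numbers stand for weaker inhibition and lower numbers for stronger inhibition
compound 2, `CC(=O)c1ccc(C(=O)N[C@@H](C)Cn2ccc(-c3ccc(C#N)c(Cl)c3)n2)cc1`: 1400 nM in this assay
compound 3, `CC(Cn1ccc(-c2ccc(C#N)c(Cl)c2)n1)C(=O)Nc1cccc(C(C)O)c1`: only the limit > 30000 nM in this assay

Compounds 1 and 2 share one core, while compound 3 is built from the same atoms joined differently; the difference between the two cores is not broken down here. From compound 1 to compound 2 the change is acetyl in place of 1-hydroxyethyl on an aromatic carbon, and it gave a 1.5-fold higher number from compound 1 to compound 2 (0.19 log units; within the scatter). Compound 4, `CC(=O)c1cccc(NC(=O)C(C)Cn2ccc(-c3ccc(C#N)c(Cl)c3)n2)c1`, carries the same kind of change relative to compound 3, (acetyl in place of 1-hydroxyethyl on an aromatic carbon), now at a place meta to a large group rather than para to a large group. Compound 4 is expected to show a step that the limit leaves unreadable from compound 3 to compound 4, because compound 3 already stands at the limit of > 30000 nM in this assay, at which 1 of the 3 values shown sits, and the earlier step of a 1.5-fold higher number from compound 1 to compound 2 (0.19 log units; within the scatter) stayed within the scatter. Compound 4 is therefore estimated at 40000 nM, with a range from 15000 nM to 120000 nM.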

Compound 4, half-maximal inhibitory concentration: 2980 nM
Compound 4: the middle estimate sits 13-fold (1.13 log units) above what was measured, and the stated range ends above it.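

Acetyl in place of 1-hydroxyethyl gave an at least 10-fold lower number from compound 3 to compound 4 (1.00 log units; beyond the scatter) in this assay, and this result did not match the one on the other core: the same change on two cores in this assay, a 1.5-fold higher number (0.19 log units; within the scatter) from compound 1 to compound 2 and an at least 10-fold lower number (1.00 log units; beyond the scatter) from compound 3 to compound 4, at least 15-fold (1.18 log units) apart, beyond the scatter of two such steps

As far as these compounds go, for compound 3 the value > 30000 nM is a limit and not a number, so the full size of that step is unknown. The change therefore did not carry over between these two cores, but two pairs give neither a rule for other cores nor a reason for the gap.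

The compounds shown leave open how an amine, a carboxylic acid or a longer chain would behave in this place on either core. They also leave open whether the gap between the two cores would persist with such groups.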